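This account rests on a few compounds, and the source may have more. Where it says the series, first, only, none or still open, it means among the compounds named here.

Measured so far:
- Compound 1, `O=C(Nc1ncc(C(=O)O)c2nc(-c3ccco3)nn12)NC1CCCCC1`: 59400 nM
- Compound 2, `CCNc1ncc(C(=O)O)c2nc(-c3ccco3)nn12`: 480 nM

Both numbers come from an assay on CHO cells for displacement of a labelled ligand from adenosine receptor A3 (Homo sapiens); on this read-out higher numbers stand for weaker inhibition and lower numbers for stronger inhibition. Going by the values given here, compound 2 stands lowest of the two numbers here; its nearest neighbour is compound 1, and the single step that links them, a 120-fold lower number from compound 1 to compound 2 (2.09 log units; beyond the scatter), is large and lies well beyond the scatter.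

Compound 3 `Cc1ccc(CNc2ncc(C(=O)O)c3nc(-c4ccco4)nn23)cc1` has not yet been measured in this assay. It differs from compound 2 in one place: 4-methylphenyl in place of methyl on a saturated chain carbon bound to a nitrogen on an aromatic ring. Cut one bond further out, the same difference reads ethyl to 4-methylbenzyl. Among the compounds with values here, no measured step bears directly on this change: the only step in hand replaces cyclohexylcarbamoyl with ethyl on the ring nitrogen and says nothing about extending the chain on that nitrogen into a 4-methylbenzyl. The expectation therefore rests on compound 2 alone, with wide uncertainty. For compound 3 the step is estimated as a 1.6-fold lower number from compound 2 to compound 3 (0.20 log units; within the scatter), which may fall within the scatter. Compound 3 is thus estimated at 300 nM, with a range from 50 nM to 1800 nM.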

Compound 3, inhibition constant: 751 nM
Estimate against measurement, compound 3: 2.5-fold (0.40 log units) below, within the range that was stated.
By their numbers in this assay, from the lowest: compounds 2 and 3 (each within the scatter of the next); then compound 1.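

In this assay, the nitrogen on the aromatic ring takes a much larger group without any readable shift: a 1.6-fold higher number from compound 2 to compound 3 (0.19 log units; within the scatter) stays within the scatter, although 7 heavy atoms, including a six-membered aromatic ring of carbon only, enter where 1 heavy atom leaves. The second step, a 79-fold lower number from compound 1 to compound 3 (1.90 log units; beyond the scatter), is large and beyond the scatter, so the wide gap first seen with ethyl also appears with 4-methylbenzyl, and two quite different groups on this nitrogen both give far lower numbers than cyclohexylcarbamoyl. No measured evidence is available to explain either of these outcomes.

As far as these compounds go, it remains open whether the methyl on the phenyl ring contributes anything, which a plain benzyl or a methoxybenzyl on the same nitrogen would help to settle. It is also unclear how far this tolerance extends, for instance to a longer chain such as butyl or to a benzyl carrying an amine, and whether any such group would move the number beyond the scatter in either direction.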